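The source may hold more compounds than are shown below. What is called first, only, known or untested is meant among the compounds shown, and "the series" means these compounds.

Compound 1 `C=C1CC[C@@H]2[C@](C)(CNCc3ccc(O)c(O)c3)[C@H](O)CC[C@@]2(C)[C@@H]1/C=C/C1=CCOC1=O` and compound 2 `C=C1CC[C@@H]2[C@](C)(CNCc3ccc([N+](=O)[O-])cc3)[C@H](O)CC[C@@]2(C)[C@@H]1/C=C/C1=CCOC1=O` share one core and differ only in the aryl group on the saturated chain carbon bound to the amine nitrogen. In a functional assay on BMMC cells (Mus musculus, strain C57BL/6) for inhibition, with stated times of 5 days and 48 h (a lower number here means a stronger inhibitor, a higher number a weaker inhibitor), compound 1 gives 9440 nM, while compound 2 gives 1340 nM; the change of 4-nitrophenyl in place of 3,4-dihydroxyphenyl brought a 7.0-fold lower number from compound 1 to compound 2 (0.85 log units; beyond the scatter). Among the compounds with values here, compound 2 therefore stands as the lowest of the two numbers in this assay, with compound 1 its only neighbour and well beyond the scatter above it.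

Compound 3 `C=C1CC[C@@H]2[C@](C)(CNCc3nccs3)[C@H](O)CC[C@@]2(C)[C@@H]1/C=C/C1=CCOC1=O` carries the change (1,3-thiazol-2-yl in place of 4-nitrophenyl on a saturated chain carbon bound to an amine nitrogen). Within the data shown here, the single step seen so far concerns a different replacement and bears on it only loosely; it shows that the 4-nitrophenyl group now leaving was the one that gave compound 2 its lower number. Compound 3 is therefore expected to move back toward weaker inhibition, an expected step of a 2.6-fold higher number from compound 2 to compound 3 (0.42 log units; beyond the scatter). The estimated value of compound 3 is 3500 nM, expected to fall between 1000 nM and 12000 nM.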

Compound 3, half-maximal inhibitory concentration: 700 nM
Compound 3: middle estimate off by 5.0-fold (0.70 log units), on the high side; the measured number lies below the stated range.
By their numbers in this assay, from the lowest: compounds 3 and 2 (each within the scatter of the next); then compound 1.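

In this assay, the replacement of the six-membered 4-nitrophenyl by the five-membered 1,3-thiazol-2-yl gives a 1.9-fold lower number from compound 2 to compound 3 (0.28 log units; within the scatter), so the two groups are not told apart on the saturated chain carbon bound to the amine nitrogen. This position therefore accepts an aromatic ring with hetero atoms and no nitro group without leaving the range of compound 2, which the earlier pair could not show. Compound 3 also confirms the gap to the 3,4-dihydroxyphenyl group, with a 13-fold lower number from compound 1 to compound 3 (1.13 log units; beyond the scatter), and no measurement at hand accounts for these numbers.

The compounds shown leave open whether a plain phenyl or a pyridine ring on this carbon would fall in the same range. They also leave open whether a single hydroxyl on the phenyl ring would resemble the 3,4-dihydroxyphenyl group of compound 1.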